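Cytotoxicity limits on a shared core under a methyl-for-hydrogen change

The source may report more compounds than this note shows. Statements on the series, on what has been measured and on what is new or still open speak of the compounds shown alone.

Four compounds built on one shared core are compared here for their tolerance by human cells. Compound 1 `COc1ccc(C(=O)CSc2nc(Cc3cc(C(F)(F)F)cc(C(F)(F)F)c3)c(C)c(=O)[nH]2)cc1` and compound 2 `COc1ccc(C(=O)CSc2nc(C(c3ccccc3)c3ccccc3)c(C)c(=O)[nH]2)cc1` differ from each other in a larger part of the molecule, and that difference between the two cores is not broken down here. In an ADME assay on MT4 cells (Homo sapiens) for cytotoxicity (a lower number here means that less compound is tolerated, a higher number that more compound is tolerated), compound 1 reaches only a limit of the assay, > 242000 nM. In this assay compound 2 likewise gives only a limit, > 274000 nM. Compound 3 `CCc1c(Cc2cc(C(F)(F)F)cc(C(F)(F)F)c2)nc(SCC(=O)c2ccc(OC)cc2)[nH]c1=O` is obtained from compound 1 by methyl in place of hydrogen on a saturated chain carbon bound to an aromatic carbon. In this assay compound 3 again gives a limit and no number, > 236000 nM. The step that the two limits leave unreadable from compound 1 to compound 3 cannot be sized, since the value of compound 1 sits at the limit of > 242000 nM in this assay, at which 1 of the 3 values shown sits, and that of compound 3 at the limit of > 236000 nM in this assay, at which 1 of the 3 values shown sits.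

Compound 4 `CCc1c(C(c2ccccc2)c2ccccc2)nc(SCC(=O)c2ccc(OC)cc2)[nH]c1=O` stands to compound 2 as compound 3 stands to compound 1: it arises by the same change, (methyl in place of hydrogen on a saturated chain carbon bound to an aromatic carbon). Compound 2 itself sits at the limit of > 274000 nM in this assay, at which 1 of the 3 values shown sits, and the same change applied to compound 1 left compound 3 at a limit as well. On that basis compound 4 is expected to be tolerated at a similar level, and it is estimated to give about 270000 nM in this assay, most likely reported as a limit rather than a number, with a plausible range from 200000 nM to 400000 nM. That estimate means an expected step of an at least 1.0-fold lower number from compound 2 to compound 4 (0.00 log units; that floor lies within the scatter).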

Compound 4, half-maximal cytotoxic concentration: > 266000 nM
Compound 4 ended at the assay's limit (the forecaster's own chance of this, stated with the estimate: 90%); the middle value is on the limit's open side.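

In this assay compound 4 gives > 266000 nM as a limit of the assay and not a number. Compound 2 likewise gives > 274000 nM as a limit, so no step can be read from compound 2 to compound 4. With all four compounds at limits, the compounds shown leave open at what concentration any of them becomes cytotoxic, and whether methyl in place of hydrogen changes that concentration.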